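Fluorophenyl Amide Variant in a Triazole Orexin Series

This account rests on a few compounds, and the source may have more. Where it says the series, first, only, none or still open, it means among the compounds named here.

Among the compounds with values here, compound 2 `COc1ccc(C)cc1NC(=O)CSc1nnc(-c2ccoc2C)n1Cc1ccco1` is the only member of this set with a number in a functional assay on CHO cells for antagonist activity at Orexin/Hypocretin receptor type 1 (Homo sapiens), read by FLIPR and calcium flux (on this read-out lower numbers stand for stronger inhibition and higher numbers for weaker inhibition), where compound 2 gives 2510 nM. Compound 1 `Cc1cccc(C)c1NC(=O)CSc1nnc(-c2ccoc2C)n1Cc1ccco1` gives only > 15800 nM in this assay, which is a limit and not a number. Within the data shown here, the single measured step, an at least 6.2-fold lower number from compound 1 to compound 2 (0.79 log units; beyond the scatter), shows that the aryl group on the amide-type nitrogen moves the read-out, and its size is bounded only by the limit of > 15800 nM in this assay, at which 1 of the 2 values shown sits.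

Compound 3 `Cc1occc1-c1nnc(SCC(=O)Nc2ccc(F)cc2)n1Cc1ccco1` carries 4-fluorophenyl in place of 2-methoxy-5-methylphenyl on an amide-type nitrogen. This exchange removes the methoxy and methyl groups that distinguish compound 2 from compound 1 and brings in a plainer aryl group, so the step from compound 1 to compound 2 bears on it only loosely. A modest rise in the number is therefore expected, as the step of a 2.4-fold higher number from compound 2 to compound 3 (0.38 log units; beyond the scatter) expresses. Compound 3 is estimated at 6000 nM, with a range from 1500 nM to 25000 nM.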

Compound 3, inhibition constant: > 15800 nM
Compound 3 was reported as a limit (the forecaster's own chance of this, stated with the estimate: 35%); middle value at least 2.6-fold (0.42 log units) from the limit.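

Exchanging the aryl group on the amide-type nitrogen for 4-fluorophenyl gives an at least 6.2-fold higher number from compound 2 to compound 3 (0.79 log units; beyond the scatter), so a second aryl group, after the 2,6-dimethylphenyl of compound 1, falls short of the 2-methoxy-5-methylphenyl of compound 2. In this assay compound 3 gives > 15800 nM, which is a limit and not a number. The step between compound 1 and compound 3 cannot be read, and the rise from compound 2 is bounded on one side only: the limit of > 15800 nM in this assay, at which 2 of the 3 values shown sit.

The compounds shown leave open whether the methoxy or the methyl group of compound 2 accounts for its measurable value. They also leave open whether another group on the amide-type nitrogen, such as a chlorophenyl or a pyridyl group, would give a lower number than compound 2.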